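This account rests on a few compounds, and the source may have more. Where it says the series, first, only, none or still open, it means among the compounds named here.

Measured in an ADME assay on L1210/0 cells (Mus musculus) for cytotoxicity, with a stated time of 48 h; on this read-out higher numbers stand for weaker inhibition and lower numbers for stronger inhibition:

Compound 1 `CC(=O)OC(C)Cn1cnc2c(Cl)nc(I)nc21`: 13000 nM
Compound 2 `CC(=O)OC(C)Cn1cnc2c(N)nc(I)nc21`: > 200000 nM (a limit of the assay, not a number)

Compound 2 stands at the limit of > 200000 nM in this assay, at which 1 of the 2 values shown sits, and this is a limit, not a number.

Compound 3 `Nc1nc(I)nc2c1ncn2COCCO` keeps the core and the amino group of compound 2. It differs on a saturated chain carbon bound to an aromatic nitrogen, where it has 2-hydroxyethoxy in place of 1-acetoxyethyl on a saturated chain carbon bound to an aromatic nitrogen.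

Within the data shown here, the one measured step is an at least 15-fold higher number from compound 1 to compound 2 (1.18 log units; beyond the scatter), with amino in place of chloro on an aromatic carbon. That step is large, and compound 3 retains the amino group that it introduced. Among the measured compounds shown here, no measured step changes the chain, so the swap itself has no direct guide in this assay. Weak inhibition is therefore expected to persist, with no step beyond the scatter expected in either direction. The expected change is a number no higher from compound 2 to compound 3 (the limit leaves the size open). For compound 3 the estimate is 200000 nM, with an expected range from 60000 nM to 400000 nM.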

Compound 3, half-maximal inhibitory concentration: > 200000 nM
Compound 3: only a limit was reported (the forecaster's own chance of this, stated with the estimate: 70%); the middle value sits exactly at the limit.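

Compound 2 and compound 3 each give only a limit of the assay rather than a number in this assay, so the step between them cannot be read: the limit of > 200000 nM in this assay, at which 2 of the 3 values shown sit.

The compounds shown leave open whether 2-hydroxyethoxy in place of 1-acetoxyethyl changes the read-out at all, and in which direction.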